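This account rests on a few compounds, and the source may have more. Where it says the series, first, only, none or still open, it means among the compounds named here.

Measured in an ADME assay on J774.A1 cells (Mus musculus) for cytotoxicity, read by MTT assay, with a stated time of 48 h; on this read-out higher numbers stand for lower toxicity in this test and lower numbers for higher toxicity in this test:
- compound 1 `COC(=O)c1c([N+](=O)[O-])noc1-c1ccc(Cl)cc1Cl`: 19700 nM
- compound 2 `COC(=O)c1c(NCc2ccc(Cl)cc2)noc1-c1ccc([N+](=O)[O-])cc1`: 78300 nM
- compound 3 `COC(=O)c1c(NCc2ccccc2)noc1-c1ccc(Cl)cc1Cl`: 54200 nM

Compound 3 stands with compound 2 at the top of these three numbers, the two lying within the scatter of each other, while compound 1 lies beyond the scatter on the lower side.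

Compound 4 `COC(=O)c1c(NCc2ccc(Cl)cc2)noc1-c1ccc(Cl)cc1Cl` is still unmeasured. It differs from compound 3 by one change, (chloro in place of hydrogen on an aromatic carbon), which is chloro in place of hydrogen on an aromatic carbon, turning benzyl into 4-chlorobenzyl.

Among the measured compounds shown here, only one measured step exists, a 2.8-fold higher number from compound 1 to compound 3 (0.44 log units; beyond the scatter). It is modest and concerns benzylamino in place of nitro, a different change at a different place, so it sets no direct size for this one. Compound 2 also holds a 4-chlorobenzyl group and gives 78300 nM, a number within the scatter of that of compound 3. This offers only indirect support for a small effect.

From the compounds shown here alone, no step beyond the scatter is therefore expected in this assay, and the direction remains open. The estimated change is a 1.1-fold lower number from compound 3 to compound 4 (0.04 log units; within the scatter). For compound 4 the expected value is 50000 nM, with an estimated range from 22000 nM to 110000 nM.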

Compound 4, half-maximal cytotoxic concentration: 176000 nM
Compound 4: the middle estimate sits 3.5-fold (0.55 log units) below what was measured, outside the stated range (above it).
By their numbers in this assay, from the lowest: compound 1; then compounds 3 and 2 (each within the scatter of the next); then compound 4.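

In this assay, the change from benzyl to 4-chlorobenzyl is not neutral at this position: chloro in place of hydrogen on an aromatic carbon gives a 3.2-fold higher number from compound 3 to compound 4 (0.51 log units; beyond the scatter), a step on the side of lower toxicity in this test. The other aryl group also matters with the 4-chlorobenzyl group held constant, since 2,4-dichlorophenyl in place of 4-nitrophenyl gives a 2.2-fold higher number from compound 2 to compound 4 (0.35 log units; beyond the scatter), again on the side of lower toxicity in this test. These two steps show that compound 4 reads apart from both compound 2 and compound 3, and no measurement is available to explain why the added chloro has this effect.

It remains open whether the chloro step carries over when 4-nitrophenyl replaces 2,4-dichlorophenyl, since the compounds shown do not include the pair needed for that comparison. It is also unknown whether the step is specific to chloro or would recur with fluoro, methoxy or a carboxylic acid at the same position, so a single pair supports no general trend for this site across the series.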